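Swapping the side chain of compound 2

The source may report more compounds than this note shows. Statements on the series, on what has been measured and on what is new or still open speak of the compounds shown alone.

In a physicochemical assay for lipophilicity, read by HPLC, at pH 7.4 (a higher number here means a more lipophilic compound, a lower number a more polar compound), compound 1 (`CC(=O)NC1C2CC3CC1CC(C2)C31OO[C@]2(CC[C@@H](c3ccc(OCC(=O)O)cc3)CC2)O1`) gives 1.8 and compound 2 (`O=C(O)CNC(=O)COc1ccc([C@H]2CC[C@]3(CC2)OOC2(O3)C3CC4CC(C3)CC2C4)cc1`) gives 3. Compound 2 is the higher of the two, by a gap beyond the usual scatter. These two compounds differ in more than one place, so that gap cannot be assigned to any single change.

The next compound to read is compound 3 (`O=C(O)CCCCOc1ccc([C@H]2CC[C@]3(CC2)OOC2(O3)C3CC4CC(C3)CC2C4)cc1`), which departs from compound 2 by 3-carboxypropyl in place of (carboxymethyl)carbamoyl on a saturated chain carbon bound to an oxygen on an aromatic ring. Within the data shown here, no measured pair isolates this change, so what follows is a judgement from the structures alone. An upward move is expected in this assay, with an estimated size of a number 0.50 log units higher from compound 2 to compound 3 (beyond the scatter), modestly beyond the scatter. For compound 3 the estimated value is 3.5, with an expected range of 2.9 to 4.1.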

Compound 3, distribution coefficient: 4
For compound 3 the middle estimate is 0.50 log units below the measured one; measured number inside the range.
By their numbers in this assay, from the lowest: compound 1; then compound 2; then compound 3.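

In this assay, among these compounds, the step of a number 1.00 log units higher from compound 2 to compound 3 (beyond the scatter) is the first reading tied to one place, with 3-carboxypropyl in place of (carboxymethyl)carbamoyl on a saturated chain carbon bound to an oxygen on an aromatic ring. The earlier gap between compound 1 and compound 2 spanned more than one place, whereas this pair shows that the number responds to the side chain at this position alone, at least for this one change. No supporting measurement bears on why the step has this size.

The pair does not separate the loss of the amide from the change in chain. As far as these compounds go, whether an amine or a tetrazole in place of the carboxylic acid, or a longer chain, would move the number in the same direction remains open.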